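The source may hold more compounds than are shown below. What is called first, only, known or untested is meant among the compounds shown, and "the series" means these compounds.

Measured in a functional assay on A549 cells (Homo sapiens) for cytotoxicity, read by MTT assay, with a stated time of 72 h; a higher number here means a weaker inhibitor, a lower number a stronger inhibitor:
- compound 1 `O=C1c2c[n+]([O-])c3ccccc3c2C(=O)c2c1c1ccccc1n2CCN1CCCC1`: 410 nM
- compound 2 `CN1CCN(CCCCCn2c3c(c4ccccc42)C(=O)c2c[n+]([O-])c4ccccc4c2C3=O)CC1`: 870 nM

Compound 2 has the higher of the two numbers, so it is the weaker inhibitor of this pair. Compound 3 `O=C1c2c[n+]([O-])c3ccccc3c2C(=O)c2c1c1ccccc1n2CCCN1CCC(O)CC1` is not yet measured, and it differs from compound 2 on a saturated chain carbon, three bonds along the chain from an aromatic nitrogen: 4-hydroxypiperidin-1-yl in place of 2-(4-methylpiperazin-1-yl)ethyl on a saturated chain carbon, three bonds along the chain from an aromatic nitrogen. Going by the values given here, only one measured step bears on this change, a 2.1-fold higher number from compound 1 to compound 2 (0.33 log units; beyond the scatter), which also altered the side chain and was modest. A step no larger than that is therefore expected in this assay, perhaps toward a lower number. The expected step is a 1.5-fold lower number from compound 2 to compound 3 (0.16 log units; within the scatter). For compound 3 the estimate is 600 nM, with an expected range of 220 nM to 1600 nM.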

Compound 3, half-maximal inhibitory concentration: 350 nM
Estimate against measurement, compound 3: 1.7-fold (0.23 log units) above, and the stated range covers the measured number.
By their numbers in this assay, from the lowest: compounds 3 and 1 (each within the scatter of the next); then compound 2.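

Replacing 5-(4-methylpiperazin-1-yl)pentyl with 3-(4-hydroxypiperidin-1-yl)propyl gives a 2.5-fold lower number from compound 2 to compound 3 (0.40 log units; beyond the scatter) in this assay, so changes at this side chain can lower the number as well as raise it. The comparison with the pyrrolidin-1-yl compound gives a 1.2-fold lower number from compound 1 to compound 3 (0.07 log units; within the scatter), so these two side chains cannot be told apart here. Ring and chain length change together from compound 2 to compound 3, so their separate contributions cannot be read. Still open, as far as these compounds go, are an unsubstituted piperidin-1-yl on the propyl chain and 5-(4-hydroxypiperidin-1-yl)pentyl, which would separate the hydroxyl group and the chain length. No measurement shown explains these differences.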